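Replacing the piperazine with phenyl on a uracil-type core

A few compounds are considered here, and "the series" means these few. Any claim that something is new, unique, unknown or untested is made for them only; others in the source may bear on it.

Measured so far:
- compound 1, `CCCCCCNC(=O)n1cc(Cl)c(=O)[nH]c1=O`: 67 nM
- compound 2, `CCCCCCNC(=O)n1cc(C(F)(F)F)c(=O)[nH]c1=O`: 12 nM
- compound 3, `CCCCCCNC(=O)n1cc(N2CCN(C)CC2)c(=O)[nH]c1=O`: 1400 nM

All three share a hexyl-bearing carbamoyl core and differ only in the group on one aromatic carbon. In an assay on HEK293 cells for inhibition of acid ceramidase (Rattus norvegicus), read by LC-MS, with a stated time of 30 min (on this read-out higher numbers stand for weaker inhibition and lower numbers for stronger inhibition), compound 3 gives the highest number of the three and is therefore the weakest inhibitor shown: it stands a 21-fold higher number from compound 1 to compound 3 (1.32 log units; beyond the scatter) and a 120-fold higher number from compound 2 to compound 3 (2.07 log units; beyond the scatter).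

Compound 4, `CCCCCCNC(=O)n1cc(-c2ccccc2)c(=O)[nH]c1=O`, is not yet measured. Its change from compound 3 is phenyl in place of 4-methylpiperazin-1-yl on an aromatic carbon. For the measured compounds named here, no measured step introduces phenyl, so the direct precedent is missing. What the measured steps do show is that putting 4-methylpiperazin-1-yl in place of a small carbon-only or halogen group raised the number by a large margin in both steps above. Removing that group again in favour of phenyl, a group without hydrogen-bond acceptors like those in compounds 1 and 2, is therefore expected to bring a large drop in this assay, roughly an 18-fold lower number from compound 3 to compound 4 (1.24 log units; beyond the scatter), with the phenyl's own effect unknown and widening the range. Compound 4 is estimated at 80 nM, between 20 nM and 400 nM.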

Compound 4, half-maximal inhibitory concentration: 177 nM
Beside the measured number, compound 4's estimate is 2.2-fold (0.34 log units) below it, within the range that was stated.
By their numbers in this assay, from the lowest: compound 2; then compound 1; then compound 4; then compound 3.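

Phenyl, a six-membered aromatic ring of carbon only, fares better here than the six-membered non-aromatic ring of 4-methylpiperazin-1-yl in this assay, giving a 7.9-fold lower number from compound 3 to compound 4 (0.90 log units; beyond the scatter), so a ring at this position does not by itself bring the full loss seen with compound 3. It still falls short of the smaller groups, with a 2.6-fold higher number from compound 1 to compound 4 (0.42 log units; beyond the scatter) and a 15-fold higher number from compound 2 to compound 4 (1.17 log units; beyond the scatter), which places phenyl in the middle of the four groups compared. Nothing available explains this order.

Cyclohexyl, a non-aromatic ring of carbon only, could show whether the loss with compound 3 follows the ring nitrogens or the non-aromatic ring. Going by these compounds, it also remains open how a 4-fluorophenyl or pyridyl ring, or a methyl or nitrile group, would compare with phenyl and trifluoromethyl.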